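Removing One of Two Trifluoromethyl Groups from Compound 3

The source may hold more compounds than are shown below. What is called first, only, known or untested is meant among the compounds shown, and "the series" means these compounds.

Three compounds share a core and were tested in a functional assay on Bel-7402 cells (Homo sapiens) for antiproliferative activity, read by sulforhodamine B assay, tested at 100 ug/mL; a lower number here means less inhibition, a higher number more inhibition at the concentration tested (going by the name of the read-out). Compound 1 `O=C1CCCCC1S(=O)(=O)Nc1ccc(Cl)cc1C(F)(F)F` gives 21%. Compound 2 `O=C1CCCCC1S(=O)(=O)Nc1ccc(Cl)cc1` gives 4.47%. Compound 3 `O=C1CCCCC1S(=O)(=O)Nc1cc(C(F)(F)F)cc(C(F)(F)F)c1` gives 66.9%, the highest of the three. The difference between the cores of compound 3 and compound 1 is not broken down here.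

Going from compound 1 to compound 2 means hydrogen in place of trifluoromethyl on an aromatic carbon and a number 16.5 percentage points lower from compound 1 to compound 2 (beyond the scatter).

Compound 4 `O=C1CCCCC1S(=O)(=O)Nc1cccc(C(F)(F)F)c1` has not yet been measured. Going from compound 3 to compound 4 means (hydrogen in place of trifluoromethyl on an aromatic carbon). Among the measured compounds shown here, this is the same kind of change as the one from compound 1 to compound 2, but not the same: there the removed group sat ortho to a large group and meta to a chloro group, whereas here it sits meta to a large group and meta to a trifluoromethyl group.

Compound 4 is expected to fall in this assay by roughly a number 38.9 percentage points lower from compound 3 to compound 4 (beyond the scatter), a larger step than the earlier one, because compound 1, which also keeps a single trifluoromethyl group, gives 21%. The estimate for compound 4 is 28%, between 8% and 50%.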

Compound 4, a percentage reported as inhibition, at one concentration (the size of the read-out at that concentration, not a potency): 11.4%
Compound 4: the middle estimate sits 16.6 percentage points above what was measured, within the range that was stated.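

In this assay, putting hydrogen in place of one trifluoromethyl group gives a number 55.5 percentage points lower from compound 3 to compound 4 (beyond the scatter), a large step. The same swap lowers the number on both cores, so its direction holds across these two pairs, but its size does not carry over from one core to the other: the same change on two cores in this assay, a number 16.5 percentage points lower (beyond the scatter) from compound 1 to compound 2 and a number 55.5 percentage points lower (beyond the scatter) from compound 3 to compound 4, 39 percentage points apart, beyond the scatter of two such steps

This shows that the size of the step depends on the rest of the molecule, yet two pairs cannot reveal which difference between the cores sets that size, or what the swap would do on a further core.

As far as these compounds go, what stays open is whether trifluoromethyl itself matters or whether other groups on that aromatic carbon would read the same way, since only trifluoromethyl and hydrogen are compared there. A nitrile, a methoxy group or an amine in that place would help to separate these possibilities, and readings across several concentrations would show whether the same steps appear as differences in potency.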